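Two Compounds at the Limit, a Propyl Replacement Ahead

The source may hold more compounds than are shown below. What is called first, only, known or untested is meant among the compounds shown, and "the series" means these compounds.

Compound 1, `Nc1ncnc2c1ncn2C1O[C@@H](C(O)O)[C@H](O)[C@H]1O`: in an ADME assay on L1210/0 cells (Mus musculus) for cytotoxicity, with a stated time of 48 h (a higher number here means a weaker inhibitor, a lower number a stronger inhibitor), compound 1 gives > 200000 nM.
Compound 2, `O=c1[nH]c(=O)n([C@H]2C[C@H](O)[C@@H](CO)O2)cc1C#CCO`: in this assay compound 2 gives > 200000 nM.

Both values are limits of the assay rather than numbers. Compound 2 stands at the limit of > 200000 nM in this assay, at which 2 of the 2 values shown sit, so its potency is known only as lying beyond that boundary. For the measured compounds named here, compound 1 sits at the same limit, and no step between the two can be read from this.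

Compound 3 is `CCCCC#Cc1cn([C@H]2C[C@H](O)[C@@H](CO)O2)c(=O)[nH]c1=O`. It differs from compound 2 in one place: propyl in place of hydroxy on a saturated chain carbon bound to a triple-bonded carbon. Going by the values given here, no measured step links the two, so the expectation rests on the unchanged core and the shared limit alone. The step of a number no higher from compound 2 to compound 3 (the limit leaves the size open) is expected to stay within the scatter, with no shift in either direction that the data would support. For compound 3 the estimate in this assay is 200000 nM, within 50000 nM to 1000000 nM, most likely reported again as a limit.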

Compound 3, half-maximal inhibitory concentration: > 200000 nM
Compound 3 ended at the assay's limit; the forecaster's own chance of this, stated with the estimate: 80%; the middle value lies on the limit itself.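

In this assay compound 3 gives > 200000 nM as a limit of the assay, not a number. For the compounds shown here, compound 2 also stands at a limit, so no step from compound 2 to compound 3 can be read. The compounds shown leave open how far beyond that limit each one lies.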